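The source may report more compounds than this note shows. Statements on the series, on what has been measured and on what is new or still open speak of the compounds shown alone.

Series notes. Going by the values given here, in an in vitro assay on BTI-TN-5B1-4 cells for inhibition of Amine oxidase [flavin-containing] A (Homo sapiens), tested at 100 uM (a higher number here means more inhibition at the concentration tested (going by the name of the read-out), a lower number less inhibition), compound 2 `Cc1ccc(-c2cc(=O)c3ccc(C)cc3o2)cc1` gives 40%, the only number in the set. Compound 1 `COc1ccc(-c2cc(=O)c3ccc(OC)cc3o2)cc1`, in this assay, is reported as "not active" (no number reported), with no figure attached; it differs from compound 2 in more than one place, so the two values simply stand side by side. Compound 3 `COc1ccc(-c2cc(=O)c3ccc(C)cc3o2)cc1` is still to be measured in this assay. Change from compound 2: methoxy in place of methyl on an aromatic carbon. A downward step is expected, a number 15 percentage points lower from compound 2 to compound 3 (beyond the scatter), modest yet possibly beyond the scatter, since compound 1 was reported as "not active" (no number reported). Compound 3 is estimated at 25%, range 5% to 45%.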

Compound 3, a percentage reported as inhibition, at one concentration (the size of the read-out at that concentration, not a potency): 40%
For compound 3 the middle estimate is 15 percentage points below the measured one; the range from low to high includes it.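

In this assay, methoxy in place of methyl on an aromatic carbon, para to a large group, leaves the number level: no change at the digits printed from compound 2 to compound 3 (within the scatter). Compound 1 carries the same methoxy at this position and is reported as "not active" (no number reported), so methoxy here does not by itself go with that report. Nothing at hand explains why the methyl and methoxy compounds read alike. Open, from the compounds shown here alone, is whether an amine, a carboxylic acid or a longer chain such as ethoxy at this position would keep the inhibition. Also open, going by these compounds, is how far any of these would differ at a concentration other than the single one tested.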